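Swapping Chlorine for Bromine on a Ring Double Bond

The source may report more compounds than this note shows. Statements on the series, on what has been measured and on what is new or still open speak of the compounds shown alone.

Compound 1 `CCCCCCC[C@H]1C[C@H](Cl)CCN1S(=O)(=O)c1ccc(C)cc1` gives 54000 nM in a functional assay on WiDr cells (Homo sapiens) for antiproliferative activity, read by sulforhodamine B assay, with a stated time of 48 h; a lower number here means a stronger inhibitor of growth, a higher number a weaker inhibitor of growth.
Compound 2 `Cc1ccc(S(=O)(=O)N2CCC(Cl)=CC2c2ccccc2)cc1` gives 18000 nM in this assay.

Of the compounds shown here, two have been measured so far, both built on a sulfonyl-substituted six-membered ring carrying a halogen. Compound 2 has the lowest number of the two, and its nearest neighbour is compound 1, whose number is higher by a margin that goes beyond the usual scatter. Compound 2 is therefore the stronger growth inhibitor of the pair in this assay.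

Compound 3 `Cc1ccc(S(=O)(=O)N2CCC(Br)=CC2c2ccccc2)cc1` has not yet been measured. It differs from compound 2 in one place only: bromo in place of chloro on a double-bonded ring carbon. Chlorine and bromine are neighbouring halogens, and the rest of the molecule is unchanged, so this is a small change. Among the measured compounds shown here, with no measured pair showing the effect of such a swap, the expectation is a step of little or no size, not beyond the scatter, in either direction. Compound 3 is thus expected to give about 15000 nM in this assay, within a range of 6000 nM to 45000 nM, which corresponds to an estimated step of a 1.2-fold lower number from compound 2 to compound 3 (0.08 log units; within the scatter).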

Compound 3, concentration for 50% growth inhibition: 29000 nM
Compound 3: the middle estimate sits 1.9-fold (0.29 log units) below what was measured; the measured number falls inside the stated range.
By their numbers in this assay, from the lowest: compounds 2, 3 and 1 (each within the scatter of the next, the first and the last beyond it).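

In this assay, placing bromo instead of chloro on the double-bonded ring carbon gives a 1.6-fold higher number from compound 2 to compound 3 (0.21 log units; within the scatter), so this first one-place comparison cannot tell the two halogens apart. Among the compounds shown here, this carbon lies two ring bonds from the ring atom bearing the phenyl group and three ring bonds from the ring nitrogen, and at this position the larger halogen atom does not produce a change that stands out from ordinary repeat-to-repeat variation, though a single pair shows only this one swap on this one core. No supporting measurement is available to explain the result, so the comparison records what happened without giving a reason for it.

On these data alone, it remains open whether a group of a different kind at this carbon, such as an amine, a carboxylic acid or a methoxy group, would move the number beyond the scatter, or whether fluoro or iodo would behave like chloro and bromo. As far as these compounds go, it is also open whether the same swap would give a similar result if a longer chain replaced the phenyl group on the ring.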